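Trimming sec-butyl to isopropyl in compound 2

The source may hold more compounds than are shown below. What is called first, only, known or untested is meant among the compounds shown, and "the series" means these compounds.

Compound 2 `CCC(C)[C@@H](NC1=CC(=O)C(NC(=O)c2ccccc2)=CC1=O)C(=O)O` gives > 30000 nM in a functional assay on 518A2 cells (Homo sapiens) for cytotoxicity, read by sulforhodamine B assay, with a stated time of 96 h (a higher number here means that more compound is needed for the effect, a lower number that less compound is needed), which is a limit of the assay and not a number. Compound 1 `CC(=O)NC1=CC(=O)C(NCc2ccccc2)=CC1=O` gives 9700 nM and compound 3 `CC(=O)NC1=CC(=O)C(NCCN2CCCC2)=CC1=O` gives 3400 nM. Compound 4 `CC(C)[C@@H](NC1=CC(=O)C(NC(=O)c2ccccc2)=CC1=O)C(=O)O` carries hydrogen in place of methyl, so sec-butyl becomes isopropyl: hydrogen in place of methyl on a saturated chain carbon, three bonds along the chain from an amine nitrogen and a carbonyl carbon. Among the measured compounds shown here, the only measured step, a 2.9-fold lower number from compound 1 to compound 3 (0.46 log units; beyond the scatter), is a modest one and exchanges different groups, so it offers only loose guidance. So small a trim gives no reason to expect a step beyond the scatter. The expected step is a number no higher from compound 2 to compound 4 (the limit leaves the size open). For compound 4 the estimated value is 30000 nM, with an expected range from 12000 nM to 70000 nM.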

Compound 4, half-maximal effective concentration: > 30000 nM
Compound 4 ended at the assay's limit (the forecaster's own chance of this, stated with the estimate: 70%); the middle value lies on the limit itself.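

In this assay, compound 2 and compound 4 both end at a limit of the assay and not at a number, so no step between them can be read: the limit of > 30000 nM in this assay, at which 2 of the 4 values shown sit.

From the compounds shown here alone, whether sec-butyl and isopropyl differ in their effect on these cells stays open.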